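A few compounds are considered here, and "the series" means these few. Any claim that something is new, unique, unknown or untested is made for them only; others in the source may bear on it.

The study compares a set of compounds in a functional assay on NCI-H1299 cells (Homo sapiens) for antiproliferative activity, read by MTT assay, with a stated time of 72 h; a lower number here means a stronger inhibitor, a higher number a weaker inhibitor. Compound 1, `CCCCCOC1=C(C(=O)c2ccccc2)C(c2ccc(Br)cc2)N(CCCn2ccnc2)C1=O`, gives 10300 nM in this assay. Compound 2, `CCOc1ccc(NC2=C(C(=O)c3ccccc3)C(c3ccc(Br)cc3)N(CCCn3ccnc3)C2=O)cc1`, gives 20000 nM in this assay. Of the two numbers recorded, compound 2 has the higher, and its nearest neighbour is compound 1, with a step that reads a 1.9-fold higher number from compound 1 to compound 2 (0.29 log units; within the scatter).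

Compound 3 is `O=C(C1=C(Nc2ccc(Br)cc2)C(=O)N(CCCn2ccnc2)C1c1ccc(Br)cc1)c1ccccc1`. It differs from compound 2 by bromo in place of ethoxy on an aromatic carbon. Going by the values given here, no measured pair in this set changes a bromo for an ethoxy, or alters the substituent on this six-membered aromatic ring of carbon only, so nothing recorded bears directly on the step. Among the compounds with values here, the one step that is known, from compound 1 to compound 2, alters a different group entirely and is itself within the scatter. With no guide pointing one way, the expected change from compound 2 to compound 3 in this assay is no change at the digits printed from compound 2 to compound 3 (within the scatter), that is, none beyond the scatter. Compound 3 is therefore estimated to give 20000 nM in this assay, with a range from 6000 nM to 60000 nM.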

Compound 3, half-maximal inhibitory concentration: 19300 nM
Estimate against measurement, compound 3: 1.0-fold (0.02 log units) above; the range from low to high includes it.
By their numbers in this assay, from the lowest: compounds 1, 3 and 2 (each within the scatter of the next).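

In this assay, the ring bearing the amino link now shows a substituent exchange of its own: bromo in place of ethoxy on an aromatic carbon, para to a large group, gives a 1.0-fold lower number from compound 2 to compound 3 (0.02 log units; within the scatter). Replacing ethoxy, with its oxygen and three heavy atoms, by a single bromine atom therefore produces no step beyond the scatter at this position, something the earlier pair could not show, since it altered only the group on the double-bonded ring carbon. On that same carbon, (4-bromophenyl)amino in place of pentyloxy gives a 1.9-fold higher number from compound 1 to compound 3 (0.27 log units; within the scatter), so this amino group, like (4-ethoxyphenyl)amino, stays within the scatter of the pentyloxy compound.

The compounds shown leave open whether an amine, a carboxylic acid or a longer alkoxy chain on this aromatic carbon would give a number beyond the scatter, since ethoxy and bromo are the only two groups seen there. Nothing available explains why these numbers lie so close together.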